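Replacing the indole on the amide with a fluorophenyl

This account rests on a few compounds, and the source may have more. Where it says the series, first, only, none or still open, it means among the compounds named here.

Compound 1 `Fc1ccc(C(SCCNC2CCN(Cc3ccc(C(F)(F)F)cc3)CC2)c2ccc(F)cc2)cc1` gives 190 nM in an assay on membranes from striatum (strain Sprague-Dawley) for displacement of a labelled ligand from sodium-dependent dopamine transporter (Rattus norvegicus), read by scintillation counting, with a stated time of 120 min; a higher number here means a weaker inhibitor, a lower number a stronger inhibitor.
Compound 2 `O=C(c1ccc(F)cc1)N1CCC(NCCSC(c2ccc(F)cc2)c2ccc(F)cc2)CC1` gives 7.04 nM in this assay.
Compound 3 `O=C(c1cc2ccccc2[nH]1)N1CCC(NCCSC(c2ccc(F)cc2)c2ccc(F)cc2)CC1` gives 177 nM in this assay.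

Compound 3 sits second highest of the three numbers. Its value and that of compound 1 lie within the scatter of each other, so nothing separates them; compound 2 stands far apart, as shown by a 25-fold higher number from compound 2 to compound 3 (1.40 log units; beyond the scatter).

Compound 4 `O=C(c1ccccc1F)N1CCC(NCCSC(c2ccc(F)cc2)c2ccc(F)cc2)CC1` has not been measured. It differs from compound 3 in one place: 2-fluorophenyl in place of 1H-indol-2-yl on a carbonyl carbon. Among the measured compounds shown here, the measured step that bears on this is the one between compound 2 and compound 3, where a 25-fold higher number from compound 2 to compound 3 (1.40 log units; beyond the scatter) came from putting the indole onto the carbonyl in place of a fluorophenyl. For the measured compounds named here, the move to compound 4 undoes that swap, though with the fluorine on a different position of the ring, for which no measured pair gives guidance. A large step downward is therefore expected, an 8.9-fold lower number from compound 3 to compound 4 (0.95 log units; beyond the scatter), though somewhat short of the full reversal. Compound 4 is estimated at 20 nM, with a range from 5 nM to 80 nM in this assay.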

Compound 4, inhibition constant: 46.1 nM
Estimate against measurement, compound 4: 2.3-fold (0.36 log units) below, within the range that was stated.
By their numbers in this assay, from the lowest: compound 2; then compound 4; then compounds 3 and 1 (each within the scatter of the next).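

At this carbonyl carbon, a fluorophenyl group alone does not guarantee the low number seen for compound 2: in this assay, exchanging 4-fluorophenyl for 2-fluorophenyl gives a clear loss (a 6.5-fold higher number from compound 2 to compound 4 (0.82 log units; beyond the scatter)), so where the fluorine sits on the ring matters. Even so, 2-fluorophenyl still does better than 1H-indol-2-yl (a 3.8-fold lower number from compound 3 to compound 4 (0.58 log units; beyond the scatter)). The (2-fluorophenyl)carbonyl group also does better than 4-(trifluoromethyl)benzyl on the amine nitrogen in the ring (a 4.1-fold lower number from compound 1 to compound 4 (0.62 log units; beyond the scatter)), a step that the indole amide, compound 3, did not achieve.

No measurement at hand explains why these changes have these effects. From the compounds shown here alone, whether a plain phenyl, or a ring carrying chlorine or a methoxy group in place of the fluorine, would match compound 2 remains open.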